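A Hydroxy Step Repeated on a Second Core

The compounds below may be only part of what the source reports. "The series", "measured", "known", "first", "only" and "open" are said of these compounds alone.

Compound 1 `O=C1C=C(N2CCN(c3ccccc3)CC2)C(=O)c2ccccc21`: 9900 nM
Compound 2 `O=C1C(N2CCN(c3ccccc3)CC2)=CC(=O)c2c(O)cccc21`: 15200 nM
Compound 3 `Cc1ccccc1C1CCN(C2=CC(=O)c3ccccc3C2=O)CC1`: 6100 nM

All three numbers come from a functional assay on DU-145 cells (Homo sapiens) for inhibition, read by MTT assay, with a stated time of 72 h; on this read-out higher numbers stand for weaker inhibition and lower numbers for stronger inhibition. Compound 2 differs from compound 1 by hydroxy in place of hydrogen on an aromatic carbon, and this step was a 1.5-fold higher number from compound 1 to compound 2 (0.19 log units; within the scatter). Compound 3 lies within the scatter of compound 1, while its number is lower than that of compound 2; the difference between the core of compound 1 and the core of compound 3 is not broken down here. Compound 4 `Cc1ccccc1C1CCN(C2=CC(=O)c3cccc(O)c3C2=O)CC1` has not been measured in this assay. It differs from compound 3 by hydroxy in place of hydrogen on an aromatic carbon, the same change as from compound 1 to compound 2. Because that earlier change gave a 1.5-fold higher number from compound 1 to compound 2 (0.19 log units; within the scatter), the expected step here is a 1.5-fold higher number from compound 3 to compound 4 (0.17 log units; within the scatter). Compound 4 is therefore estimated at 9000 nM, with a likely range from 4000 nM to 20000 nM.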

Compound 4, half-maximal inhibitory concentration: 2500 nM
Compound 4: the middle estimate sits 3.6-fold (0.56 log units) above what was measured, and the stated range ends above it.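

In this assay, hydroxy in place of hydrogen on an aromatic carbon gave a 2.4-fold lower number from compound 3 to compound 4 (0.39 log units; beyond the scatter), so the change did not behave on the core of compound 3 as it had on the core of compound 1. The two steps differ by more than the usual scatter: the same change on two cores in this assay, a 1.5-fold higher number (0.19 log units; within the scatter) from compound 1 to compound 2 and a 2.4-fold lower number (0.39 log units; beyond the scatter) from compound 3 to compound 4, 3.7-fold (0.57 log units) apart, beyond the scatter of two such steps. This shows that, for these two pairs, the step measured on one core was a poor guide to the step on the other, but it does not show which structural difference sets them apart, nor does it give a rule for any further core.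

The compounds shown leave open whether a methoxy group or an amine at the same place on the core of compound 3 would also lower the number. They also leave open whether a second hydroxy group would add to the step.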